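The compounds below may be only part of what the source reports. "The series", "measured", "known", "first", "only" and "open" are said of these compounds alone.

For the measured compounds named here, in a physicochemical assay for lipophilicity, read by LC-MS, using the shake flask method, in phosphate buffer, with a stated time of 50 min, at pH 7.4 (on this read-out higher numbers stand for higher lipophilicity and lower numbers for lower lipophilicity), compound 2 `CCCC(=O)NCCCCCC(=O)N[C@H](C(=O)N1C[C@H](O)C[C@H]1C(=O)NCc1ccc(-c2scnc2C)cc1)C(C)(C)C` gives 2.2, the higher of the two numbers so far, and compound 1 `CCCC(=O)OCCCCCC(=O)N[C@H](C(=O)N1C[C@H](O)C[C@H]1C(=O)NCc1ccc(-c2scnc2C)cc1)C(C)(C)C` gives 0.5. Compound 3 `COCC(=O)NCCCCCC(=O)N[C@H](C(=O)N1C[C@H](O)C[C@H]1C(=O)NCc1ccc(-c2scnc2C)cc1)C(C)(C)C` differs from compound 2 in one group: methoxy in place of ethyl on a saturated chain carbon bound to a carbonyl carbon, which means methoxy in place of ethyl on a saturated chain carbon bound to a carbonyl carbon. Going by the values given here, the only measured step, a number 1.70 log units higher from compound 1 to compound 2 (beyond the scatter), is a different exchange at a different place, so it bears only loosely, though the compound with oxygen at the changed place stood lower there. The expected step in this assay is smaller and downward: a number 0.60 log units lower from compound 2 to compound 3 (beyond the scatter). For compound 3 the estimate is 1.6, within an expected range from 1 to 2.1.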

Compound 3, distribution coefficient: 2.2
Compound 3: the middle estimate sits 0.60 log units below what was measured, and the stated range ends below it.
By their numbers in this assay, from the lowest: compound 1; then compounds 2 and 3 (each within the scatter of the next).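

In this assay, methoxy in place of ethyl on a saturated chain carbon bound to a carbonyl carbon gives no change at the digits printed from compound 2 to compound 3 (within the scatter), so this exchange of a carbon for an oxygen leaves the two compounds level. ((Methoxymethyl)carbonyl)amino in place of (propylcarbonyl)oxy gives a number 1.70 log units higher from compound 1 to compound 3 (beyond the scatter), so among these three compounds the large gap follows the amino-or-oxy link rather than the ethyl-or-methoxy exchange. Nothing measured here gives a reason for either step. From the compounds shown here alone, whether an amine, a carboxylic acid or a longer chain at this place would also leave the number level stays open.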